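Acetylation of a Hydroxyl in a Compound Beyond the Assay Limit

The source may report more compounds than this note shows. Statements on the series, on what has been measured and on what is new or still open speak of the compounds shown alone.

Compound 1, `C=C1C(=O)O[C@]2(C)CC[C@@H]1C[C@H](O)[C@@]1(C)CC[C@H](O1)[C@](C)(O)CC[C@H]2OC(C)=O`: > 20 ug/mL
Compound 2, `C=C1C(=O)O[C@]2(C)CC[C@@H]1C[C@H](O)[C@@]1(C)CC[C@H](O1)C(=C)CC[C@H]2OC(C)=O`: > 20 ug/mL

Both results in a functional assay on HEp-2 cells (Homo sapiens) for cytotoxicity (a higher number here means a weaker inhibitor, a lower number a stronger inhibitor), are limits of the assay rather than numbers. For compound 1 the value > 20 ug/mL is such a limit. For compound 2 the value > 20 ug/mL is likewise a limit, so compound 2 stands at the edge of what this assay reports, with no number to place it further. The two compounds thus show nothing more than that they share the same limit; (the limit of > 20 ug/mL in this assay, at which 2 of the 2 values shown sit).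

Compound 3, `C=C1C(=O)O[C@]2(C)CC[C@@H]1C[C@H](OC(C)=O)[C@@]1(C)CC[C@H](O1)C(=C)CC[C@H]2OC(C)=O`, differs from compound 2 in one place: acetyl in place of hydrogen on an oxygen on a saturated carbon. With only limits to go on, no measurable step is expected, and the step that the limit leaves unreadable from compound 2 to compound 3 is estimated to stay within the usual scatter. Compound 3 is therefore expected to give about 30 ug/mL in this assay, within a range from 15 ug/mL to 60 ug/mL, most likely again reported only as a limit.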

Compound 3, half-maximal inhibitory concentration: > 20 ug/mL
Compound 3 ended at the assay's limit (the forecaster's own chance of this, stated with the estimate: 80%); the middle value does not contradict the limit.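

Among these compounds, compound 2 and compound 3 both sit at a limit in this assay and not at a number, so no step between them can be read. From the compounds shown here alone, whether hydroxy to acetoxy changes the result in this assay at all, and where any of the three compounds truly lies, stays open.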